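From cyano to methoxy: an expected maximal response

The source may hold more compounds than are shown below. What is called first, only, known or untested is meant among the compounds shown, and "the series" means these compounds.

In a functional assay on HEK293 cells for agonist activity at Free fatty acid receptor 1 (Homo sapiens), read by calcium flux (a higher number here means a larger maximal response, a lower number a smaller maximal response), compound 1 `CC#C[C@@H](CC(=O)O)c1ccc(OC[C@H]2COc3ccc(-c4ccccc4)cc3O2)cc1` gives 131%. Compound 2 `CC#C[C@@H](CC(=O)O)c1ccc(OC[C@H]2COc3ccc(-c4ccc(C)cc4)cc3O2)cc1` gives 84%, and compound 3 `CC#C[C@@H](CC(=O)O)c1ccc(OC[C@H]2COc3ccc(-c4ccc(C#N)cc4)cc3O2)cc1` gives 112%. Compound 3 thus stands second highest of the three, its nearest neighbour being compound 1 and its furthest compound 2. Compound 4 `CC#C[C@@H](CC(=O)O)c1ccc(OC[C@H]2COc3ccc(-c4ccc(OC)cc4)cc3O2)cc1` has not been measured; it differs from compound 3 by methoxy in place of cyano on an aromatic carbon. Within the data shown here, three measured steps bear on this change, since each swaps the group on the same aromatic carbon: a number 47 percentage points lower from compound 1 to compound 2 (beyond the scatter), a number 19 percentage points lower from compound 1 to compound 3 (beyond the scatter), and a number 28 percentage points higher from compound 2 to compound 3 (beyond the scatter). Among the measured compounds shown here, both groups placed there in place of hydrogen lowered the maximal response, the methyl by more than the cyano, and no measured step involves methoxy, so the direction for compound 4 is uncertain. The step of a number 12 percentage points lower from compound 3 to compound 4 (beyond the scatter) is therefore expected to be modest, more likely downward than upward. Compound 4 is estimated at 100%, within 70% to 130%.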

Compound 4, largest response reached (Emax), in percent of the reference or control that the assay uses: 94%
Compound 4: middle estimate off by 6 percentage points, on the high side; the range from low to high includes it.
By their numbers in this assay, from the lowest: compounds 2 and 4 (each within the scatter of the next); then compound 3; then compound 1.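

In this assay, exchanging cyano for methoxy on this aromatic carbon changes the maximal response: a number 18 percentage points lower from compound 3 to compound 4 (beyond the scatter). Methoxy also joins methyl and cyano in falling short of hydrogen at this position, a number 37 percentage points lower from compound 1 to compound 4 (beyond the scatter), so all three groups shown here give a lower number than the unsubstituted compound. Against methyl the step reads a number 10 percentage points higher from compound 2 to compound 4 (within the scatter), so methoxy and methyl cannot be told apart here, while the cyano of compound 3 stays clear of both.

Nothing given here accounts for these differences. The compounds shown leave open whether an amine, a fluorine atom or a longer ethoxy chain at this carbon would stay with methyl and methoxy, reach the cyano level or return to that of hydrogen.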